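Replacing the tert-butylphenyl tail in a thiourea series

This account rests on a few compounds, and the source may have more. Where it says the series, first, only, none or still open, it means among the compounds named here.

Compound 1 `COc1cc(CNC(=S)NC(CCc2ccc(C(C)(C)C)cc2)COC(=O)C(C)(C)C)cc(Cl)c1O` and compound 2 `COc1cc(CNC(=S)NC(CCc2ccc(C(C)(C)C)cc2)COC(=O)C(C)(C)C)c(Br)cc1O` were tested in an assay on CHO cells for displacement of a labelled ligand from transient receptor potential cation channel subfamily V member 1 (Rattus norvegicus); a higher number here means a weaker inhibitor, a lower number a stronger inhibitor. Compound 1 gives 122 nM, the higher of the two numbers recorded, and compound 2 gives 75 nM, a change of a 1.6-fold lower number from compound 1 to compound 2 (0.21 log units; within the scatter). Compound 3 `COc1cc(CNC(=S)NC(CCc2ccc(C)c(C)c2)COC(=O)C(C)(C)C)cc(Cl)c1O` differs from compound 1 by 3,4-dimethylphenyl in place of 4-(tert-butyl)phenyl on a saturated chain carbon, three bonds along the chain from an amide-type nitrogen. Going by the values given here, no measured step touches this part of the molecule, so the single known step, which alters the other aryl group, offers no guide in either direction. Compound 3 is therefore expected to show an uncertain step of a 2.5-fold higher number from compound 1 to compound 3 (0.39 log units; beyond the scatter) in this assay, estimated at 300 nM with a range from 80 nM to 1200 nM.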

Compound 3, inhibition constant: 86 nM
Beside the measured number, compound 3's estimate is 3.5-fold (0.54 log units) above it, and the stated range covers the measured number.
By their numbers in this assay, from the lowest: compounds 2, 3 and 1 (each within the scatter of the next).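

In this assay, going by these compounds alone, the first measured step at this position, on a saturated chain carbon three bonds along the chain from an amide-type nitrogen, is a 1.4-fold lower number from compound 1 to compound 3 (0.15 log units; within the scatter). Thus 3,4-dimethylphenyl can stand in place of 4-(tert-butyl)phenyl without a difference beyond the scatter. No evidence is available that would explain this result. Going by these compounds, it remains open whether a tail bearing an amine or a carboxylic acid would also stay within the scatter of compound 1. Also open, on these data alone, is how 3,4-dimethylphenyl behaves alongside the 2-bromo-4-hydroxy-5-methoxyphenyl group of compound 2.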